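The source may hold more compounds than are shown below. What is called first, only, known or untested is meant among the compounds shown, and "the series" means these compounds.

Measured in an ADME assay on MT4 cells (Homo sapiens) for cytotoxicity, read by MTT assay, with a stated time of 5 days; on this read-out higher numbers stand for lower toxicity in this test and lower numbers for higher toxicity in this test:
- Compound 1 `Cc1cnc(Nc2ccc(C#N)cc2)nc1OCC(=O)Nc1ccc(F)cc1`: > 331000 nM (a limit)
- Compound 2 `Cc1cnc(Nc2ccc(C#N)cc2)nc1OCC(=O)Nc1cccc(Cl)c1`: 144000 nM

Among the compounds with values here, compound 2 holds the only actual number, 144000 nM. The entry for compound 1 is a limit, not a number. Compound 3 `Cc1cnc(Nc2ccc(C#N)cc2)nc1OCC(=O)Nc1ccc(Br)cc1` has 4-bromophenyl in place of 3-chlorophenyl on an amide-type nitrogen. Within the data shown here, one measured step bears on this: an at least 2.2-fold lower number from compound 1 to compound 2 (0.36 log units; beyond the scatter). Compound 3 shares a 4-substituted phenyl with compound 1, so a partial return along that step is expected in this assay. The expected change is a 1.4-fold higher number from compound 2 to compound 3 (0.14 log units; within the scatter), a rise that stays within the scatter. Compound 3 is estimated at 200000 nM, with an expected range of 70000 nM to 450000 nM.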

Compound 3, half-maximal cytotoxic concentration: 34700 nM
Compound 3: the middle estimate sits 5.8-fold (0.76 log units) above what was measured, outside the stated range (below it).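

A 4-substituted phenyl on the amide-type nitrogen does not by itself keep the number high in this assay: 4-bromophenyl in place of 3-chlorophenyl gives a 4.1-fold lower number from compound 2 to compound 3 (0.62 log units; beyond the scatter). Bromo in place of fluoro on an aromatic carbon gives an at least 9.5-fold lower number from compound 1 to compound 3 (0.97 log units; beyond the scatter), so the identity of the halogen matters among these compounds. The entry for compound 1 is a limit, so this step has no exact size: the limit of > 331000 nM in this assay, at which 1 of the 3 values shown sits.

The compounds shown leave open how 4-chlorophenyl or 3-bromophenyl would read, which would separate the halogen from its place. They also leave open how a 4-methoxyphenyl would read here.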